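The compounds below may be only part of what the source reports. "The series", "measured", "known", "first", "only" and "open" are said of these compounds alone.

Compound 3, `COC(=O)[C@@]1(C)CC[C@@H]2C3=C1CC[C@@H](C)[C@]3(C)C[C@@H]1c3cc(F)ccc3N[C@H]21`, gives 25000 nM in a functional assay on A549 cells (Homo sapiens) for inhibition, read by sulforhodamine B assay, with a stated time of 48 h; on this read-out lower numbers stand for stronger inhibition of growth and higher numbers for weaker inhibition of growth. Its number sits at the low end of the three measured compounds, yet all three lie within the usual scatter of one another: compound 2, `COC(=O)[C@@]1(C)CC[C@@H]2C3=C1CC[C@@H](C)[C@]3(C)C[C@@H]1c3cc(C)ccc3N[C@H]21`, gives 27000 nM, and compound 1, `COC(=O)[C@@]1(C)CC[C@@H]2C3=C1CC[C@@H](C)[C@]3(C)C[C@@H]1c3ccccc3N[C@H]21`, gives 39000 nM. The relevant steps are a 1.6-fold lower number from compound 1 to compound 3 (0.19 log units; within the scatter) and a 1.1-fold lower number from compound 2 to compound 3 (0.03 log units; within the scatter), both small. Compound 4, `COC(=O)[C@@]1(C)CC[C@@H]2C3=C1CC[C@@H](C)[C@]3(C)C[C@@H]1c3cc(OC)ccc3N[C@H]21`, differs from compound 3 by methoxy in place of fluoro on an aromatic carbon. Within the data shown here, no measured step swaps fluoro for methoxy, but both earlier changes at this aromatic carbon stayed within the scatter, so no step beyond the scatter is expected in this assay. Compound 4 is therefore estimated at 26000 nM, with a range from 12000 nM to 55000 nM, an expected step of a 1.0-fold higher number from compound 3 to compound 4 (0.02 log units; within the scatter).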

Compound 4, concentration for 50% growth inhibition: 22000 nM
The estimate for compound 4 lay 1.2-fold (0.07 log units) above the measured number; the measured number falls inside the stated range.
By their numbers in this assay, from the lowest: compounds 4, 3, 2 and 1 (each within the scatter of the next).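

In this assay, among these compounds, methoxy, the first group here to bring a hydrogen-bond acceptor to this aromatic carbon, gives a 1.1-fold lower number from compound 3 to compound 4 (0.06 log units; within the scatter) and a 1.2-fold lower number from compound 2 to compound 4 (0.09 log units; within the scatter) and a 1.8-fold lower number from compound 1 to compound 4 (0.25 log units; within the scatter) and all three steps stay within the scatter. Hydrogen, methyl, fluoro and methoxy at this carbon therefore give numbers that cannot be told apart. Nothing measured here offers an explanation for this flat result. From the compounds shown here alone, whether an amine or a carboxylic acid at this carbon would move the number beyond the scatter remains open. Also open, going by these compounds, is how any of these groups would behave on the other aromatic carbons of this ring.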